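Carbamoyl in place of a protected aminomethyl on the ring

A few compounds are considered here, and "the series" means these few. Any claim that something is new, unique, unknown or untested is made for them only; others in the source may bear on it.

Of the compounds shown here, three sharing one core have been measured in an assay on HEK293 cells for displacement of a labelled ligand from NPC1-like intracellular cholesterol transporter 1 (Homo sapiens); a lower number here means a stronger inhibitor, a higher number a weaker inhibitor. Compound 1 `CC(C)(C)OC(=O)NCC1CCCN(C(=O)CN2CN(c3ccccc3)C3(CCN(C(=O)c4ccc(C5CCCCC5)cc4)CC3)C2=O)C1` gives 3800 nM, compound 2 `CC(C)(C)OC(=O)NCNC(=O)CN1CN(c2ccccc2)C2(CCN(C(=O)c3ccc(C4CCCCC4)cc3)CC2)C1=O` gives 1700 nM, and compound 3 `CC(C)(C)OC(=O)NCC1CCCN(C(=O)CN2CN(c3ccccc3)C3(CCN(C(=O)c4ccc(C(C)(C)C)cc4)CC3)C2=O)C1` gives 9500 nM. Among the compounds with values here, compound 3 thus stands highest of the three, beyond the scatter from both others; the only single-point step that reaches it is a 2.5-fold higher number from compound 1 to compound 3 (0.40 log units; beyond the scatter), a modest weakening.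

Compound 4 `CC(C)(C)c1ccc(C(=O)N2CCC3(CC2)C(=O)N(CC(=O)N2CCCC(C(N)=O)C2)CN3c2ccccc2)cc1` differs from compound 3 in one place: carbamoyl in place of ((tert-butoxycarbonyl)amino)methyl on a saturated ring carbon. Within the data shown here, no measured step touches this part of the molecule, so the step from compound 1 to compound 3 says nothing directly about it, and the gap between compound 1 and compound 2 involves a different change to the linker rather than this ring substituent. With no guide, the expected outcome is close to no change beyond the scatter, with wide uncertainty in either direction. For compound 4 the estimate in this assay is 7000 nM, within 2000 nM to 25000 nM, which would be a step of a 1.4-fold lower number from compound 3 to compound 4 (0.13 log units; within the scatter).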

Compound 4, half-maximal inhibitory concentration: 16900 nM
Estimate against measurement, compound 4: 2.4-fold (0.38 log units) below, within the range that was stated.
By their numbers in this assay, from the lowest: compound 2; then compound 1; then compounds 3 and 4 (each within the scatter of the next).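

Within the data shown here, replacing ((tert-butoxycarbonyl)amino)methyl with carbamoyl on this saturated ring carbon gives a 1.8-fold higher number from compound 3 to compound 4 (0.25 log units; within the scatter) in this assay, the first reading at this position. The substituent shrinks from 9 heavy atoms to 3, and the tert-butoxycarbonyl portion goes with it, yet the number does not move beyond the scatter, so in this pair neither group stands apart from the other. Nothing available accounts for this result.

From the compounds shown here alone, whether an amine or a carboxylic acid on the same ring carbon, or a longer chain ending in carbamoyl, would shift the number beyond the scatter remains open. Going by these compounds, it is also open whether carbamoyl would give the same outcome with cyclohexyl on the aromatic carbon in place of tert-butyl.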